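Dropping One Chlorine from a Weak Cell-Growth Inhibitor

The compounds below may be only part of what the source reports. "The series", "measured", "known", "first", "only" and "open" are said of these compounds alone.

Of the compounds shown here, three have been tested in a functional assay on MCF7 cells (Homo sapiens) for inhibition, read by XTT assay, with a stated time of 48 h; a lower number here means a stronger inhibitor, a higher number a weaker inhibitor. Compound 1 `COc1ccc(C(=O)/C(=C/c2ccccc2F)COC(C)=O)cc1` gives 30000 nM, compound 2 `C/C=C(\COC(=O)c1ccccc1)C(=O)c1ccc(OC)cc1` gives 29800 nM, and compound 3 `COc1ccc(C(=O)/C(=C/c2ccc(Cl)cc2Cl)CCOC(C)=O)cc1` gives 83400 nM, the highest of the three numbers; both other values lie lower by more than the usual scatter, so compound 3 is the weakest inhibitor shown. Compound 4 `COc1ccc(C(=O)/C(=C/c2ccccc2Cl)CCOC(C)=O)cc1` is its nearest relative: the change is hydrogen in place of chloro on an aromatic carbon, so a 2,4-dichlorophenyl becomes a 2-chlorophenyl. Within the data shown here, no pair of measured compounds differs in only one place, so the size of such a step has not been seen here. A modest move toward a lower number, or none beyond the scatter, is expected. Compound 4 is estimated at 50000 nM, most likely between 20000 nM and 120000 nM, meaning a step of a 1.7-fold lower number from compound 3 to compound 4 (0.22 log units; within the scatter).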

Compound 4, half-maximal inhibitory concentration: > 100000 nM
Compound 4: a limit, no number; the forecaster's own chance of this, stated with the estimate: 15%; middle value at least 2.0-fold (0.30 log units) from the limit.
By their numbers in this assay, from the lowest: compounds 2 and 1 (each within the scatter of the next); then compound 3. At a limit, above all of these: compound 4.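

In this assay compound 4 gives > 100000 nM, a limit of the assay and not a number. Putting hydrogen in place of the chloro group that sits meta to the other chloro group gives an at least 1.1-fold higher number from compound 3 to compound 4 (0.07 log units; that floor lies within the scatter), so this change brings no visible gain in inhibition. The true size of the step stays hidden, as the reading ends at the edge of the assay: the limit of > 100000 nM in this assay, at which 1 of the 4 values shown sits.

As far as these compounds go, whether an amine or a carboxylic acid at this same place would bring the number down remains open. So does whether a group other than chloro could be tolerated here at all.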